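Replacing the formyl group with a pyrrolyl ketone side chain

The compounds below may be only part of what the source reports. "The series", "measured", "known", "first", "only" and "open" are said of these compounds alone.

Measured so far:
compound 1 `COc1ccc(-c2cc3ccccc3nc2C=O)cc1` — > 10000 nM
compound 2 `COc1ccc(-c2cc3ccccc3nc2/C=C/C(=O)c2ccc(N)cc2)cc1` — 6510 nM
compound 3 `COc1ccc(-c2cc3ccccc3nc2/C=C/C(=O)c2ccsc2)cc1` — 1220 nM

In a functional assay on NCI-H1299 cells (Homo sapiens) for antiproliferative activity, read by XTT assay, with a stated time of 72 h (a higher number here means a weaker inhibitor, a lower number a stronger inhibitor), compound 1 gives > 10000 nM, which is a limit of the assay and not a number. Compound 1 therefore stands at the limit of > 10000 nM in this assay, at which 1 of the 3 values shown sits, and only a limit is known for it.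

The unmeasured compound 4 `COc1ccc(-c2cc3ccccc3nc2/C=C/C(=O)c2ccc[nH]2)cc1` differs from compound 1 by 2-((1H-pyrrol-2-yl)carbonyl)ethenyl in place of formyl on an aromatic carbon.

For the measured compounds named here, two measured steps bear on this change. The closest one is an at least 8.1-fold lower number from compound 1 to compound 3 (0.91 log units; beyond the scatter), where the same formyl group is replaced by a thienyl ketone side chain. The second is a 5.3-fold lower number from compound 2 to compound 3 (0.73 log units; beyond the scatter), which shows that the ring on the carbonyl carbon matters, with a five-membered heteroaryl giving the lower number. Going by the values given here, compound 4 carries a different five-membered heteroaryl on that carbonyl, so a step similar in direction to the one from compound 1 to compound 3 is expected, somewhat smaller in size to allow for the change of ring.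

For compound 4 the expected step is an at least 5.0-fold lower number from compound 1 to compound 4 (0.69 log units; beyond the scatter), giving an estimate of 2000 nM with a range from 700 nM to 6000 nM.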

Compound 4, half-maximal inhibitory concentration: > 10000 nM
Compound 4 gave a limit, no number; the forecaster's own chance of this, stated with the estimate: 5%; middle value at least 5.0-fold (0.69 log units) from the limit.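

In this assay compound 4 gives > 10000 nM, a limit of the assay and not a number, and it shares that limit with compound 1: the limit of > 10000 nM in this assay, at which 2 of the 4 values shown sit.

An enone side chain with a five-membered heteroaryl ketone is therefore not enough on its own at this position, as the ring on the carbonyl carbon separates the two such compounds, with an at least 8.1-fold higher number from compound 3 to compound 4 (0.91 log units; beyond the scatter). Against the 4-aminophenyl ketone there is an at least 1.5-fold higher number from compound 2 to compound 4 (0.18 log units; that floor lies within the scatter), which gives no firm order for that pair, and the step from the formyl compound cannot be read.

Thiophen-3-yl and 1H-pyrrol-2-yl differ in both hetero atom and point of attachment, so the compounds shown do not separate these two changes. A thiophen-2-yl, 1H-pyrrol-3-yl or 1-methylpyrrol-2-yl ketone would address this open question.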